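Changing the aromatic group on a shared core

The source may hold more compounds than are shown below. What is called first, only, known or untested is meant among the compounds shown, and "the series" means these compounds.

In a functional assay on CCRF-CEM cells (Homo sapiens) for antiproliferative activity, with a stated time of 72 h (a lower number here means a stronger inhibitor, a higher number a weaker inhibitor), the measured compounds stand as follows:
compound 1, `OC[C@H]1O[C@@H](n2cnc3c(NCc4ccc(Br)cc4)ncnc32)[C@H](O)[C@@H]1O`: 20600 nM
compound 2, `COc1ccc(CNc2ncnc3c2ncn3[C@@H]2O[C@H](CO)[C@@H](O)[C@H]2O)c(OC)c1`: > 166000 nM, which is a limit of the assay rather than a number.

Compound 2 thus rests at the limit of > 166000 nM in this assay, at which 1 of the 2 values shown sits, and is the weaker of the two. Going by the values given here, the only measured step, an at least 8.0-fold higher number from compound 1 to compound 2 (0.90 log units; beyond the scatter), concerns the same place but a different pair of groups, so it bears on the new step only loosely. Compound 3, `Cc1cccc(CNc2ncnc3c2ncn3[C@@H]2O[C@H](CO)[C@@H](O)[C@H]2O)c1O`, carries 2-hydroxy-3-methylphenyl in place of 2,4-dimethoxyphenyl on a saturated chain carbon bound to a nitrogen on an aromatic ring. Among the compounds with values here, no measured step covers this exchange directly, so the expected step is an at least 2.7-fold lower number from compound 2 to compound 3 (0.44 log units; beyond the scatter), toward a somewhat lower number. Compound 3 is therefore estimated at 60000 nM, with a range from 15000 nM to 200000 nM.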

Compound 3, half-maximal inhibitory concentration: 900 nM
Beside the measured number, compound 3's estimate is 67-fold (1.82 log units) above it, outside the stated range (below it).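

In this assay, the group on this saturated chain carbon can strengthen as well as weaken: 2-hydroxy-3-methylphenyl brings an at least 180-fold lower number from compound 2 to compound 3 (2.26 log units; beyond the scatter) and a 23-fold lower number from compound 1 to compound 3 (1.36 log units; beyond the scatter). The earlier compounds shown here showed only a loss, whereas this position also allows a large gain over 4-bromophenyl. Compound 2 stands at a limit of the assay rather than a number, so its step gives only a minimum size: the limit of > 166000 nM in this assay, at which 1 of the 3 values shown sits.

These groups differ in more than one feature, so the hydroxy and the methyl cannot be credited separately. On these data alone, whether an amine or a carboxylic acid in place of the hydroxy would keep the gain stays open.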